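The compounds below may be only part of what the source reports. "The series", "measured", "known", "first", "only" and "open" are said of these compounds alone.

Measured in a functional assay on K562 cells (Homo sapiens) for inhibition, read by trypan blue exclusion, with a stated time of 24 h, tested at 10 uM; on this read-out lower numbers stand for less inhibition of growth and higher numbers for more inhibition of growth at the one concentration tested:
- compound 1 `NC(=O)c1ccccc1NC(=O)COc1ccc(Cl)cc1Cl`: < 10%, a limit of the assay
- compound 2 `NC(=O)c1cc(Cl)ccc1NC(=O)COc1ccc(Cl)cc1Cl`: 18.8%
- compound 3 `NC(=O)c1cc(I)ccc1NC(=O)COc1ccccc1`: 73%

Compound 2, at 18.8%, holds the lower of the two actual numbers. Compound 3, at 73%, lies beyond the scatter from it. Compound 1 gives only a limit, < 10%.

The next compound is compound 4 `NC(=O)c1cc(I)ccc1NC(=O)COc1ccc(Cl)cc1Cl`. Its difference from compound 2 is iodo in place of chloro on an aromatic carbon, meta to a carbamoyl group. Going by the values given here, no measured step covers this exchange. Among the compounds with values here, the one step on this ring, a number at least 8.8 percentage points higher from compound 1 to compound 2 (that floor lies within the scatter), is chloro in place of hydrogen and gives only a floor. The better guide is compound 3, which carries the iodo and reaches 73%, though it has no chloro on its phenoxy group, so the guide is loose. A rise beyond the scatter is expected, of uncertain size.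

The expected change is a number 26.2 percentage points higher from compound 2 to compound 4 (beyond the scatter). For compound 4 the estimated value is 45%, with an expected range of 20% to 75%.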

Compound 4, percent growth inhibition at one concentration: 74.7%
Beside the measured number, compound 4's estimate is 29.7 percentage points below it, within the range that was stated.
By their numbers in this assay, from the lowest: compound 2; then compounds 3 and 4 (each within the scatter of the next). At a limit, below all of these: compound 1.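

In this assay there is a number 55.9 percentage points higher from compound 2 to compound 4 (beyond the scatter) for iodo in place of chloro, so with this core the choice of halogen at this position, meta to a carbamoyl group, matters, and not merely whether a halogen is present. Compound 1 gives < 10% as its entry, and that is a limit and not a number. Measured against that limit, iodo in place of hydrogen gives a number at least 64.7 percentage points higher from compound 1 to compound 4 (beyond the scatter) and clears the scatter, which the floor for chloro in place of hydrogen did not do.

With only hydrogen, chloro and iodo shown here, it stays open how bromo, a methyl group, a nitrile or an amine would read at this position. On these data alone, it is also open whether the gain seen at one concentration in one cell line carries over to a full concentration response.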